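This account rests on a few compounds, and the source may have more. Where it says the series, first, only, none or still open, it means among the compounds named here.

Series notes, measured in a functional assay on MCF7 cells (Homo sapiens) for inhibition, read by sulforhodamine B assay, with a stated time of 48 h; a lower number here means a stronger inhibitor of growth, a higher number a weaker inhibitor of growth:

- compound 1 `CCOC(=O)c1nn(-c2ccc(Cl)cc2)c(-c2ccc(Cl)cc2)c1CNC(C)(C)C`: 120000 nM; > 519000 nM (2 entries)
- compound 2 `CC(C)(C)NCc1c(C(=O)O)nn(-c2ccccc2)c1-c1ccc(Cl)cc1`: > 652000 nM (a limit)
- compound 3 `CC(C)(C)NCc1c(C(=O)O)nn(-c2ccc(Cl)cc2)c1-c1ccc(F)cc1`: 270000 nM

For the measured compounds named here, compound 3 stands at 270000 nM, the only single number in this assay for this set. Compound 2 reads > 652000 nM, which is a limit of the assay. Compound 1 has two entries, one of them a limit, and neither serves as a single value.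

Compound 4 `CC(C)(C)NCc1c(C(=O)O)nn(-c2ccc(Cl)cc2)c1-c1ccc(Cl)cc1` is not yet measured. It has chloro in place of fluoro on an aromatic carbon, para to a large group, so 4-fluorophenyl becomes 4-chlorophenyl: chloro in place of fluoro on an aromatic carbon. No measured step sizes this change, so the estimate stays close to compound 3 at 270000 nM. The expected step of a 1.1-fold higher number from compound 3 to compound 4 (0.05 log units; within the scatter) lies within the usual scatter, with no direction expected. The range is kept wide because the several entries of compound 1 in this assay, 120000 nM; > 519000 nM (2 entries) lie far apart for compound 1. For compound 4 the expected value is 300000 nM, with an estimated range of 100000 nM to 800000 nM.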

Compound 4, concentration for 50% growth inhibition: 246000 nM
Beside the measured number, compound 4's estimate is 1.2-fold (0.09 log units) above it; low and high end bracket the measured number.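

Working in this assay, the change from 4-fluorophenyl to 4-chlorophenyl, para to a large group, now has a measured size, a 1.1-fold lower number from compound 3 to compound 4 (0.04 log units; within the scatter), so fluoro and chloro at this place cannot be told apart in this pair. Chloro in place of hydrogen on an aromatic carbon gives a clearer shift, an at least 2.6-fold lower number from compound 2 to compound 4 (0.42 log units; beyond the scatter), and this is the only step in the set beyond the scatter. Compound 2 stands at a limit, so this step has only a lower bound on its size: the limit of > 652000 nM in this assay, at which 1 of the 4 values shown sits.

From the compounds shown here alone, whether a methoxy or a trifluoromethyl group at this place would depart from fluoro and chloro stays open. So does the reading for an amide in place of the carboxylic acid on the shared core.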